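The source may hold more compounds than are shown below. What is called first, only, known or untested is meant among the compounds shown, and "the series" means these compounds.

Compound 1 `Cc1ccc(N2CCCC2)c(C(=O)Nc2ccc(CNC(=O)OCc3cccnc3)cc2)c1` is built from an amide-linked core carrying a pyrrolidin-1-yl group and a methyl group on one aromatic ring. In a functional assay on MGC-803 cells (Homo sapiens) for inhibition, read by MTT assay, with a stated time of 72 h (a lower number here means a stronger inhibitor, a higher number a weaker inhibitor), compound 1 gives 19100 nM, the only numeric result available here. Compound 2 `Cc1cccc(C(=O)Nc2ccc(CNC(=O)OCc3cccnc3)cc2)c1N1CCCC1`, with the methyl moved to another position, reaches only the limit of this assay, > 100000 nM, so no number can be read for it; the limit of > 100000 nM in this assay, at which 1 of the 2 values shown sits, describes this. Compound 3 `O=C(NCc1ccc(NC(=O)c2cc(C(F)(F)F)ccc2N2CCCC2)cc1)OCc1cccnc1` differs from compound 1 by one change: trifluoromethyl in place of methyl on an aromatic carbon. Within the data shown here, no measured pair shows what such an exchange does on this core, so the expectation rests on compound 1 alone, and the step of a 1.3-fold lower number from compound 1 to compound 3 (0.10 log units; within the scatter) is expected to stay small, with no clear direction beyond the usual scatter. Compound 3 is therefore estimated at 15000 nM in this assay, with a range from 5000 nM to 50000 nM.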

Compound 3, half-maximal inhibitory concentration: 42100 nM
Beside the measured number, compound 3's estimate is 2.8-fold (0.45 log units) below it; the measured number falls inside the stated range.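

Among these compounds, at the position para to the pyrrolidin-1-yl group, trifluoromethyl in place of methyl gives the first readable step on this core in this assay: a 2.2-fold higher number from compound 1 to compound 3 (0.34 log units; beyond the scatter), so this exchange moves the result toward a weaker inhibitor, though only modestly. Among the compounds shown here, until now no such step existed, as compound 2 offers only a limit of the assay, > 100000 nM. Nothing given here accounts for the size or direction of this step.

Going by these compounds, with only methyl and trifluoromethyl at this position, no trend can be drawn, and it remains open how hydrogen, chlorine or a methoxy group there would compare. Also open, on these data alone, is whether the same exchange would shift the number similarly at the other ring position, where compound 2 carries its methyl.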